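The source may hold more compounds than are shown below. What is called first, only, known or untested is meant among the compounds shown, and "the series" means these compounds.

Within the data shown here, in a functional assay on A-375 cells (Homo sapiens) for cytotoxicity, read by MTT assay, with a stated time of 72 h (a higher number here means a weaker inhibitor, a lower number a stronger inhibitor), compound 1 `O=C1c2c[n+]([O-])c3ccccc3c2C(=O)c2c1c1ccccc1n2CCCCn1ccnc1` gives 350 nM and compound 2 `O=C1c2c[n+]([O-])c3ccccc3c2C(=O)c2c1c1ccccc1n2Cc1cn(CC(O)CO)nn1` gives 440 nM, so compound 2 stands within the scatter of the only other measured compound. Compound 3 `O=C1c2c[n+]([O-])c3ccccc3c2C(=O)c2c1c1ccccc1n2CCCCN1CCNCC1` carries 3-(piperazin-1-yl)propyl in place of 1-(2,3-dihydroxypropyl)-1H-1,2,3-triazol-4-yl on a saturated chain carbon bound to an aromatic nitrogen. Among the measured compounds shown here, the one measured change at this place, a 1.3-fold higher number from compound 1 to compound 2 (0.10 log units; within the scatter), is small, so no step beyond the scatter is expected in this assay, though a single step is thin evidence. The expected step is a 1.1-fold lower number from compound 2 to compound 3 (0.04 log units; within the scatter) and would stay within the scatter. Compound 3 is estimated at 400 nM, with a range of 150 nM to 1100 nM.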

Compound 3, half-maximal inhibitory concentration: 460 nM
Compound 3: middle estimate off by 1.2-fold (0.06 log units), on the low side; measured number inside the range.
By their numbers in this assay, from the lowest: compounds 1, 2 and 3 (each within the scatter of the next).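

In this assay, the change to 3-(piperazin-1-yl)propyl gives a 1.0-fold higher number from compound 2 to compound 3 (0.02 log units; within the scatter), while piperazin-1-yl in place of 1H-imidazol-1-yl gives a 1.3-fold higher number from compound 1 to compound 3 (0.12 log units; within the scatter), so a six-membered non-aromatic ring at this position also stays within the scatter. The entering group has 1 hydrogen-bond donor and 2 hydrogen-bond acceptors against 2 and 5 for the leaving group, yet no step among these compounds goes beyond the scatter. No supporting measurement bears on this result. Going by these compounds, whether a carboxylic acid or a longer chain at this position would give a step beyond the scatter remains open.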